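Pyrrolidin-1-yl in Place of Methyl(phenyl)amino: Compound 4

The source may hold more compounds than are shown below. What is called first, only, known or untested is meant among the compounds shown, and "the series" means these compounds.

Compound 1 `CC(=O)c1ccc(N2CCN(c3nc(=O)c4cc(C(F)(F)F)cc([N+](=O)[O-])c4s3)CC2)cc1`: in a toxicity assay on HeLa cells (Homo sapiens) for cytotoxicity, read by colorimetric assay, with a stated time of 72 h (a lower number here means that less compound is tolerated, a higher number that more compound is tolerated), compound 1 gives a limit of the assay, > 105000 nM.
Compound 2 `N#Cc1cccc(N2CCN(c3nc(=O)c4cc(C(F)(F)F)cc([N+](=O)[O-])c4s3)CC2)c1`: in this assay compound 2 also gives only a limit, > 108000 nM.
Compound 3 `CN(C(=O)CN1CCN(c2nc(=O)c3cc(C(F)(F)F)cc([N+](=O)[O-])c3s2)CC1)c1ccccc1`: in this assay compound 3 gives 70300 nM.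

Among the measured compounds shown here, compound 3 holds the only number here; the other two values are limits, as the limit of > 105000 nM in this assay, at which 1 of the 3 values shown sits, and the limit of > 108000 nM in this assay, at which 1 of the 3 values shown sits, record. The steps from those limits to compound 3 are therefore open-ended floors: an at least 1.4-fold lower number from compound 1 to compound 3 (0.17 log units; that floor lies within the scatter) and an at least 1.5-fold lower number from compound 2 to compound 3 (0.18 log units; that floor lies within the scatter), and both floors lie within the scatter. The step from compound 1 to compound 2 is unreadable because both values are limits.

Compound 4 `O=C(CN1CCN(c2nc(=O)c3cc(C(F)(F)F)cc([N+](=O)[O-])c3s2)CC1)N1CCCC1` differs from compound 3 by pyrrolidin-1-yl in place of methyl(phenyl)amino on a carbonyl carbon. The measured steps all exchange the whole group on the amine nitrogen in the ring, and none of them varies only the far end of the carbamoylmethyl chain, so they bear on this change only loosely. For the measured compounds named here, with no measured step pointing beyond the scatter, the expected step in this assay is a 1.0-fold lower number from compound 3 to compound 4 (0.00 log units; within the scatter), that is, no change beyond the scatter. Compound 4 is therefore estimated at 70000 nM, with a range from 35000 nM to 140000 nM.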

Compound 4, half-maximal cytotoxic concentration: > 106000 nM
Compound 4 gave a limit, no number (the forecaster's own chance of this, stated with the estimate: 35%); middle value at least 1.5-fold (0.18 log units) from the limit.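

Among the compounds shown here, this is the first step that varies only the far end of the chain, on a carbonyl carbon whose other neighbour is a saturated chain carbon, and in this assay it gives an at least 1.5-fold higher number from compound 3 to compound 4 (0.17 log units; that floor lies within the scatter). That floor does not establish a real change, but it does show that a carbonyl-ending chain on the amine nitrogen in the ring does not always give a readable number: compound 4 carries ((pyrrolidin-1-yl)carbonyl)methyl there and gives only a limit of the assay. The steps from compound 1 and from compound 2 to compound 4 cannot be read, as all three values are limits, so these three compounds cannot be placed in any order.

Going by these compounds, whether pyrrolidin-1-yl in place of methyl(phenyl)amino truly moves the value beyond the scatter remains open, as does the separate part played by the phenyl ring and the methyl group of compound 3. For the compounds shown here, also open is how other groups on this carbonyl carbon would read, such as dimethylamino, morpholin-4-yl or piperidin-1-yl, which would show whether the single number of compound 3 belongs to its aromatic ring or to something more general.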